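Removing a methyl from the aryl ether of compound 2

The source may hold more compounds than are shown below. What is called first, only, known or untested is meant among the compounds shown, and "the series" means these compounds.

Compound 1 `O=C(Nc1cccc(-n2cc(-c3ccncc3)c(-c3ccc(Cl)c(O)c3)n2)c1)Nc1cccc(C(F)(F)F)c1` in a functional assay on KM12 cells (Homo sapiens) for inhibition, read by sulforhodamine B assay, with a stated time of 48 h (on this read-out higher numbers stand for lower toxicity in this test and lower numbers for higher toxicity in this test), gives > 32500 nM, which is a limit of the assay rather than a number. Compound 2 `COc1cc(-c2nn(-c3cccc(NC(=O)Nc4ccc(Cl)c(Cl)c4)c3)cc2-c2ccncc2)ccc1Cl` in this assay gives 49500 nM.

Within the data shown here, compound 2 thus holds the only number here; the other value is a limit (the limit of > 32500 nM in this assay, at which 1 of the 2 values shown sits). Compound 3 `O=C(Nc1cccc(-n2cc(-c3ccncc3)c(-c3ccc(Cl)c(O)c3)n2)c1)Nc1ccc(Cl)c(Cl)c1` keeps the shared core of compound 2 and differs only by hydrogen in place of methyl on an oxygen on an aromatic ring. Among the measured compounds shown here, with no measured step to lean on, the change is expected to move the result by no more than the scatter, in no particular direction. Compound 3 is therefore estimated at 45000 nM, between 15000 nM and 120000 nM, a step of a 1.1-fold lower number from compound 2 to compound 3 (0.04 log units; within the scatter) expected to be small.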

Compound 3, concentration lethal to 50% of the cells: 26300 nM
The estimate for compound 3 lay 1.7-fold (0.23 log units) above the measured number; low and high end bracket the measured number.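

Changing methoxy to hydroxy on the 4-chloro-3-methoxyphenyl group now gives a measured step at this position in this assay, and that step is a 1.9-fold lower number from compound 2 to compound 3 (0.27 log units; within the scatter), so on this read-out the two groups cannot be told apart. Placing 3,4-dichlorophenyl in place of 3-(trifluoromethyl)phenyl on the amide-type nitrogen gives an at least 1.2-fold lower number from compound 1 to compound 3 (0.09 log units; that floor lies within the scatter). Compound 1 holds a limit rather than a number, so that step is only a floor: the limit of > 32500 nM in this assay, at which 1 of the 3 values shown sits.

On these data alone, whether an ethyl group or a longer chain on this oxygen, or an amine in its place, would move the number beyond the scatter stays open.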